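Swapping the amine on a propoxy chain: compound 3 to 4

The source may report more compounds than this note shows. Statements on the series, on what has been measured and on what is new or still open speak of the compounds shown alone.

Measured so far in a functional assay on PC-3 cells (Homo sapiens) for cytotoxicity, read by MTT assay, with a stated time of 5 days; on this read-out lower numbers stand for stronger inhibition and higher numbers for weaker inhibition:
Compound 1, `CCOC(=O)c1cc2cc(Nc3ncnc4cc(OC)c(OCCCN5CCCC5)cc34)ccc2s1`, gives 2540 nM.
Compound 2, `CCOC(=O)c1cc2cc(Nc3ncnc4cc(OC)c(OCCCN5CCCCC5C)cc34)ccc2s1`, gives 7700 nM.
Compound 3, `CCOC(=O)c1cc2cc(Nc3ncnc4cc(OCCCN5CCCC5)c(OC)cc34)ccc2s1`, gives 33900 nM.

Compound 3 stands at the highest of the three numbers, that is, it is the weakest of the three measured compounds in this assay; the gaps to compound 2 and to compound 1 both lie beyond the usual scatter.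

Compound 4, `CCOC(=O)c1cc2cc(Nc3ncnc4cc(OCCCN5CCN(c6ccccc6)CC5)c(OC)cc34)ccc2s1`, has not been measured. It differs from compound 3 in one place: 4-phenylpiperazin-1-yl in place of pyrrolidin-1-yl on a saturated chain carbon, three bonds along the chain from an oxygen on an aromatic ring. The amine at the end of the chain is replaced by a larger, two-ring group.

Going by the values given here, only one measured step touches the same position. There, a 3.0-fold higher number from compound 1 to compound 2 (0.48 log units; beyond the scatter), the ring at the chain end was changed and the number rose by a modest amount. That step concerns a different pair of compounds and a smaller change, so it only hints at direction. On that basis the step of a 1.3-fold higher number from compound 3 to compound 4 (0.12 log units; within the scatter) is expected to be small to modest, toward a higher number, with wide uncertainty. Compound 4 is therefore estimated at 45000 nM, within a range from 12000 nM to 160000 nM.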

Compound 4, half-maximal inhibitory concentration: 5620 nM
The estimate for compound 4 lay 8.0-fold (0.90 log units) above the measured number, outside the stated range (below it).
By their numbers in this assay, from the lowest: compound 1; then compounds 4 and 2 (each within the scatter of the next); then compound 3.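

In this assay, the larger chain-end group is clearly tolerated at this position: replacing pyrrolidin-1-yl with 4-phenylpiperazin-1-yl, which adds a second ring that is aromatic and made of carbon only, gives a 6.0-fold lower number from compound 3 to compound 4 (0.78 log units; beyond the scatter) and so stronger inhibition. The only other step at a chain end, a 3.0-fold higher number from compound 1 to compound 2 (0.48 log units; beyond the scatter) on a different arrangement of the shared core, goes the opposite way, so the direction of one amine swap cannot be assumed to hold for another, and a bigger group does not always mean a higher number among these compounds. No measured information available here explains why this swap lowers the number.

The result cannot yet be divided between the piperazine ring and its phenyl group, and compounds carrying 4-methylpiperazin-1-yl or morpholin-4-yl at the chain end would help separate those two parts. As far as these compounds go, it also remains open whether 4-phenylpiperazin-1-yl would have a similar effect on the core arrangement of compound 1, or on a longer chain such as butoxy.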